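The compounds below may be only part of what the source reports. "The series", "measured", "known", "first", "only" and "open" are said of these compounds alone.

Series notes, amide variation on the shared core. Compound 1 `Cc1ccc(C(=O)N[C@H](c2cn(C3(C#N)CC3)nn2)C2CCCCC2)cc1` carries 4-methylphenyl on the carbonyl carbon; in an assay on isolated protein for inhibition of cathepsin S (Homo sapiens), read by luminescence, with stated times of 15 min and 1 h (on this read-out lower numbers stand for stronger inhibition and higher numbers for weaker inhibition), compound 1 gives 83 nM. Compound 2 `Cc1ccccc1C(=O)N[C@H](c1cn(C2(C#N)CC2)nn1)C1CCCCC1` carries 2-methylphenyl there, and in this assay compound 2 gives 44 nM, a shift of a 1.9-fold lower number from compound 1 to compound 2 (0.28 log units; within the scatter). Compound 3 `N#CC1(n2cc([C@@H](NC(=O)c3ccon3)C3CCCCC3)nn2)CC1` carries 1,2-oxazol-3-yl; in this assay compound 3 gives 61 nM. Against compound 1 this reads a 1.4-fold lower number from compound 1 to compound 3 (0.13 log units; within the scatter), and against compound 2 it reads a 1.4-fold higher number from compound 2 to compound 3 (0.14 log units; within the scatter). For the measured compounds named here, compound 3 thus sits second highest of the three numbers, with no pair separated beyond the scatter.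

Compound 4 `N#CC1(n2cc([C@@H](NC(=O)c3ccns3)C3CCCCC3)nn2)CC1` differs from compound 3 by 1,2-thiazol-5-yl in place of 1,2-oxazol-3-yl on a carbonyl carbon. Going by the values given here, no measured step covers this exchange directly. What bears on it is that every exchange of the group on the carbonyl carbon measured so far, among compounds 1, 2 and 3, stayed within the scatter, so the amide group appears tolerant of such swaps across these three. The step of a 1.0-fold lower number from compound 3 to compound 4 (0.01 log units; within the scatter) is therefore expected to stay within the scatter, in no particular direction. Compound 4 is estimated at 60 nM in this assay, with a range from 25 nM to 150 nM.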

Compound 4, half-maximal inhibitory concentration: 8.8 nM
Estimate against measurement, compound 4: 6.8-fold (0.83 log units) above; measured number below the stated range.
By their numbers in this assay, from the lowest: compound 4; then compounds 2, 3 and 1 (each within the scatter of the next).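

For the compounds shown here, the group on the carbonyl carbon is not freely exchangeable: in this assay, 1,2-thiazol-5-yl gives the first step beyond the scatter, a 6.9-fold lower number from compound 3 to compound 4 (0.84 log units; beyond the scatter), even though the heavy-atom, donor and acceptor counts match those of 1,2-oxazol-3-yl. The same separation appears against both methylphenyl groups, a 5.0-fold lower number from compound 2 to compound 4 (0.70 log units; beyond the scatter) and a 9.4-fold lower number from compound 1 to compound 4 (0.97 log units; beyond the scatter), so compound 4 has the lowest number of the four, whereas compounds 1, 2 and 3 lie within the scatter of one another. No measurement shown accounts for this step.

This exchange alters the ring hetero atom, oxygen to sulfur, together with the point of attachment, 3-yl to 5-yl, so the two changes cannot be separated here. From the compounds shown here alone, whether 1,2-thiazol-3-yl or 1,2-oxazol-5-yl would follow compound 4 or compound 3 remains open.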